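Notes on a pyrrolidin-1-yl swap in the series

The source may report more compounds than this note shows. Statements on the series, on what has been measured and on what is new or still open speak of the compounds shown alone.

In an ADME assay on L6 cells (Rattus norvegicus) for cytotoxicity, read by resazurin assay, with a stated time of 72 h (a lower number here means a stronger inhibitor, a higher number a weaker inhibitor), three compounds have been measured so far. Compound 1 (`CN1CCN(CC(=O)OC2CC3(N4CCCC4)CC(c4ccccc4)C2C(c2ccccc2)C3)CC1`) gives 24600 nM, compound 2 (`CCN(CC)CC(=O)OC1CC2(N3CCCCC3)CC(c3ccccc3)C1C(c1ccccc1)C2`) gives 23900 nM and compound 3 (`CN1CCN(CC(=O)OC2CC3(N4CCCCC4)CC(c4ccccc4)C2C(c2ccccc2)C3)CC1`) gives 29500 nM. Compound 3 lies within the scatter of both others, so the three cannot be ranked.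

Compound 4 (`O=C(CN1CCCC1)OC1CC2(N3CCCCC3)CC(c3ccccc3)C1C(c1ccccc1)C2`) differs from compound 3 on a saturated chain carbon bound to a carbonyl carbon: pyrrolidin-1-yl in place of 4-methylpiperazin-1-yl on a saturated chain carbon bound to a carbonyl carbon. The closest evidence at that place is a 1.2-fold higher number from compound 2 to compound 3 (0.09 log units; within the scatter), with 4-methylpiperazin-1-yl in place of diethylamino. The other measured step, a 1.2-fold higher number from compound 1 to compound 3 (0.08 log units; within the scatter), has piperidin-1-yl in place of pyrrolidin-1-yl, but on a saturated ring carbon. Going by the values given here, both steps stay within the scatter, although no measured compound yet carries pyrrolidin-1-yl on the chain carbon.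

No step beyond the scatter is expected, and the estimated step is a 1.1-fold lower number from compound 3 to compound 4 (0.05 log units; within the scatter). The estimated value for compound 4 is 26000 nM, with an expected range from 14000 nM to 48000 nM.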

Compound 4, half-maximal inhibitory concentration: 16400 nM
Compound 4: the middle estimate sits 1.6-fold (0.20 log units) above what was measured; measured number inside the range.
By their numbers in this assay, from the lowest: compounds 4, 2, 1 and 3 (each within the scatter of the next).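

At the saturated chain carbon bound to a carbonyl carbon, pyrrolidin-1-yl now has measured steps of its own in this assay: a 1.8-fold lower number from compound 3 to compound 4 (0.25 log units; within the scatter) against 4-methylpiperazin-1-yl, and a 1.5-fold lower number from compound 2 to compound 4 (0.16 log units; within the scatter) against diethylamino. Compounds 2, 3 and 4, which share piperidin-1-yl on the saturated ring carbon, therefore all lie within the scatter of one another, so these three amines at this place cannot be ranked, and the exchange of the six-membered ring with two hetero atoms for the five-membered ring with one does not move the number beyond the scatter. No evidence on hand accounts for these results.

Open, as far as these compounds go, is whether a carboxylic acid or a primary amine at this chain carbon would give a step beyond the scatter. Also open, from the compounds shown here alone, is how pyrrolidin-1-yl at this place reads when the saturated ring carbon carries pyrrolidin-1-yl as well.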